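Hydroxymethyl for methyl on the pyridine of compound 2

This account rests on a few compounds, and the source may have more. Where it says the series, first, only, none or still open, it means among the compounds named here.

Among the compounds measured so far, compound 2 `CCC(CC)CNc1c(C(N)=O)cnc2ccc(-c3ccc(C)nc3)cc12` gives the lowest number in an assay on HT-29 cells for inhibition of Serine-protein kinase ATM (Homo sapiens), read by fluorescence, with a stated time of 1 h (on this read-out higher numbers stand for weaker inhibition and lower numbers for stronger inhibition), at 50 nM. Among the measured compounds shown here, its only neighbour, compound 1 `CCC(CC)CNc1c(C(N)=O)cnc2ccc(-c3cncnc3)cc12`, gives 1840 nM in this assay, and the single measured step, a 37-fold lower number from compound 1 to compound 2 (1.57 log units; beyond the scatter), is the exchange of pyrimidin-5-yl for 6-methylpyridin-3-yl on an aromatic carbon. Compound 3 `CCC(CC)CNc1c(C(N)=O)cnc2ccc(-c3ccc(CO)nc3)cc12` is not yet measured; it differs from compound 2 by hydroxy in place of hydrogen on a saturated chain carbon bound to an aromatic carbon, that is, methyl becomes hydroxymethyl and 6-methylpyridin-3-yl becomes 6-(hydroxymethyl)pyridin-3-yl. For the measured compounds named here, no measured step bears directly on this change: the one step at hand swaps the whole ring, not a substituent on its methyl. Compound 3 is therefore expected to move by a 1.6-fold higher number from compound 2 to compound 3 (0.20 log units; within the scatter), a step not clearly beyond the scatter in either direction. The estimate for compound 3 in this assay is 80 nM, with a range from 25 nM to 250 nM.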

Compound 3, half-maximal inhibitory concentration in the Serine-protein kinase ATM assay: 87 nM
Beside the measured number, compound 3's estimate is 1.1-fold (0.04 log units) below it; the range from low to high includes it.
By their numbers in the Serine-protein kinase ATM assay, from the lowest: compounds 2 and 3 (each within the scatter of the next); then compound 1.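

In the Serine-protein kinase ATM assay compound 3 gives 87 nM: hydroxy in place of hydrogen on this saturated chain carbon bound to an aromatic carbon gives a 1.7-fold higher number from compound 2 to compound 3 (0.24 log units; within the scatter), and the exchange of pyrimidin-5-yl for 6-(hydroxymethyl)pyridin-3-yl gives a 21-fold lower number from compound 1 to compound 3 (1.33 log units; beyond the scatter), so the large step from the ring exchange survives this added oxygen. In a physicochemical assay for lipophilicity, using the shake flask method, measured as octanol-water partition, at pH 7.4 (on this read-out lower numbers stand for lower lipophilicity and higher numbers for higher lipophilicity), compound 2 gives > 4.3, which is a limit of the assay and not a number. In the physicochemical assay compound 3 gives 3.7. In the physicochemical assay the same change gives a number at least 0.60 log units lower from compound 2 to compound 3 (beyond the scatter), a lower lipophilicity with no step beyond the scatter in the Serine-protein kinase ATM assay, though the size of the drop is bounded only by a limit: the limit of > 4.3 in the physicochemical assay, at which 1 of the 2 values shown sits.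

As far as these compounds go, whether an aminomethyl group, a carboxylic acid or a longer chain such as hydroxyethyl at this place would behave the same stays open. The compounds shown also cannot tell why hydroxymethyl and methyl fall within the scatter of each other.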